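Trifluoromethyl for cyano in a series silent on cytotoxicity

The source may hold more compounds than are shown below. What is called first, only, known or untested is meant among the compounds shown, and "the series" means these compounds.

Compound 3, `Cc1ccc(S(=O)(=O)N[C@@H](CC(=O)NC(C)(C)C)C(=O)NCCNC(=O)c2cccc(C#N)c2)cc1`, carries a cyano group on an aromatic carbon of a six-membered aromatic ring of carbon only. In an ADME assay on Karpas-1106P cells (Homo sapiens) for cytotoxicity (a lower number here means that less compound is needed, a higher number that more compound is needed for the effect), compound 3 is recorded only as a limit, > 11100 nM. Its two neighbours tell the same story. Compound 1, `Cc1ccc(S(=O)(=O)N[C@@H](CC(=O)NC(C)(C)C)C(=O)NCCNC(=O)c2cccc(O)c2)cc1`, gives in this assay only a limit, > 11100 nM. Compound 2, `Cc1ccc(S(=O)(=O)N[C@@H](CC(=O)NC(C)(C)C)C(=O)NCCNC(=O)c2ccccc2Cl)cc1`, gives in this assay only a limit, > 11100 nM. The steps among the three are accordingly unreadable: a step that the two limits leave unreadable from compound 1 to compound 2, a step that the two limits leave unreadable from compound 1 to compound 3 and a step that the two limits leave unreadable from compound 2 to compound 3. What unites them is the limit of > 11100 nM in this assay, at which 3 of the 3 values shown sit.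

Compound 4, `Cc1ccc(S(=O)(=O)N[C@@H](CC(=O)NC(C)(C)C)C(=O)NCCNC(=O)c2cccc(C(F)(F)F)c2)cc1`, differs from compound 3 in one place: trifluoromethyl in place of cyano on an aromatic carbon. No measured step bears on this change with a readable size, since every step shown runs between two limits, and so the data give no direction. The step that the limit leaves unreadable from compound 3 to compound 4 is expected to be small, leaving compound 4 at the limit as well, because all three measured compounds sit at the limit of > 11100 nM in this assay, at which 3 of the 3 values shown sit. Compound 4 is therefore estimated at 20000 nM, within a range from 8000 nM to 60000 nM, and most likely reported again as a limit rather than a number.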

Compound 4, half-maximal effective concentration: > 11100 nM
Compound 4: no number, only a limit; the forecaster's own chance of this, stated with the estimate: 85%; the middle value is on the limit's open side.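

In this assay compound 4 gives only a limit, > 11100 nM, and the steps joining compound 4 to compound 1, compound 2 and compound 3 cannot be read. The four compounds share a single result: the limit of > 11100 nM in this assay, at which 4 of the 4 values shown sit.

The compounds shown leave open whether any change to the shared core would give a readable value in this assay.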